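The source may hold more compounds than are shown below. What is called first, only, known or untested is meant among the compounds shown, and "the series" means these compounds.

Compound 1 `COc1ccccc1C(=O)Nc1cccc(NC(=O)C2CCCCC2)c1` pairs a 2-methoxyphenyl amide with a cyclohexylcarbonyl amide on a shared core. In an in vitro functional assay on HEK293-A cells for antagonist activity at metabotropic glutamate receptor 5 (Rattus norvegicus), read by calcium flux (a higher number here means a weaker inhibitor, a lower number a stronger inhibitor), compound 1 gives > 30000 nM, which is a limit of the assay and not a number. Compound 2 `COc1ccccc1C(=O)Nc1cccc(NC(=O)C2CCC2)c1` differs from compound 1 in one place: cyclobutyl in place of cyclohexyl on a carbonyl carbon. In this assay compound 2 gives > 30000 nM, again a limit. The step that the two limits leave unreadable from compound 1 to compound 2 therefore cannot be sized. Compound 3 `O=C(Nc1cccc(NC(=O)C2CCCCC2)c1)c1cccc(Cl)c1` differs from compound 1 at the other amide: 3-chlorophenyl in place of 2-methoxyphenyl on a carbonyl carbon. In this assay compound 3 gives > 30000 nM, once more a limit, so the step that the two limits leave unreadable from compound 1 to compound 3 is likewise unreadable. All three measured values sit at the same ceiling, as summarised by the limit of > 30000 nM in this assay, at which 3 of the 3 values shown sit.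

Compound 4 `O=C(Nc1cccc(NC(=O)C2CCC2)c1)c1cccc(Cl)c1`, not yet measured, stands to compound 3 as compound 2 stands to compound 1: cyclobutyl in place of cyclohexyl on a carbonyl carbon. The surroundings of the change are the same in both pairs, so it is the same change; the cores of the two pairs differ as described above for compound 1 and compound 3. Compound 1 and compound 2 both ended at the limit, so a step that the two limits leave unreadable from compound 1 to compound 2 gave nothing readable there, and compound 3 itself sits at the limit. On that basis the step is expected to be a step that the limit leaves unreadable from compound 3 to compound 4. Compound 4 is therefore estimated to give about 40000 nM in this assay, most probably reported only as a limit, with a range from 15000 nM to 150000 nM.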

Compound 4, half-maximal inhibitory concentration: 5270 nM
The estimate for compound 4 lay 7.6-fold (0.88 log units) above the measured number, and the stated range ends above it.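

In this assay, cyclobutyl in place of cyclohexyl on a carbonyl carbon gives an at least 5.6-fold lower number from compound 3 to compound 4 (0.75 log units; beyond the scatter) where the other amide carries 3-chlorophenyl, whereas the same change with 2-methoxyphenyl there gave no readable step, and compound 2 stayed at the ceiling. Read the other way, 3-chlorophenyl in place of 2-methoxyphenyl gives an at least 5.6-fold lower number from compound 2 to compound 4 (0.75 log units; beyond the scatter) where cyclobutyl is present, so among the compounds shown only the combination of the two groups in compound 4 yields a measured number. This shows that the cyclobutyl change does not produce a measurable inhibitor on every core, but it does not show that the change acts differently on the two cores, since both steps are only lower bounds and the steps between two limits cannot be read: the limit of > 30000 nM in this assay, at which 3 of the 4 values shown sit.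

The compounds shown leave open how much of the result depends on ring size, since cyclopropyl and cyclopentyl on the same carbonyl carbon would fill in the series around cyclobutyl and cyclohexyl. They also leave open whether the 3-chlorophenyl can give way to another group, such as a pyridine ring or a phenyl bearing a nitrile, with the cyclobutyl amide kept in place.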